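The source may hold more compounds than are shown below. What is called first, only, known or untested is meant among the compounds shown, and "the series" means these compounds.

Measured so far:
compound 1 `ClCc1cccc(Cn2cnc3c(Cl)ncnc32)c1` — 26300 nM
compound 2 `ClCc1cccc(Cn2cnc3c(Cl)nc(Cl)nc32)c1` — 61700 nM
compound 3 `ClCc1ccccc1Cn1cnc2ncnc(Cl)c21` — 77600 nM

All three were tested in a functional assay on OVCAR-4 cells (Homo sapiens) for cytotoxicity, read by sulforhodamine B assay, with a stated time of 48 h; a higher number here means that more compound is tolerated, a lower number that less compound is tolerated. Compound 1 carries one chloro group on its two-ring core; compound 2 is the same molecule with a further chloro group, (chloro in place of hydrogen on an aromatic carbon). That single addition moved the result by a 2.3-fold higher number from compound 1 to compound 2 (0.37 log units; beyond the scatter). Compound 3 has the same atoms as compound 1 joined differently; the difference between the two cores is not broken down here. Its value and that of compound 2 lie within the usual scatter of each other, while it stands further from compound 1.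

Compound 4 `ClCc1ccccc1Cn1cnc2nc(Cl)nc(Cl)c21` has not yet been measured in this assay. It is related to compound 3 exactly as compound 2 is to compound 1: chloro in place of hydrogen on an aromatic carbon, the same change at the same kind of place. If that change acts as it did before, compound 4 is expected to give a step of a 2.2-fold higher number from compound 3 to compound 4 (0.34 log units; beyond the scatter), because the earlier step was a 2.3-fold higher number from compound 1 to compound 2 (0.37 log units; beyond the scatter). The expected value for compound 4 is therefore 170000 nM, with a likely range from 80000 nM to 350000 nM.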

Compound 4, concentration lethal to 50% of the cells: > 100000 nM
Compound 4: a limit, no number; the forecaster's own chance of this, stated with the estimate: 25%; the middle value lies beyond the limit too.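

In this assay compound 4 gives > 100000 nM as its result, and this is a limit of the assay, not a number. Chloro in place of hydrogen on the core of compound 3 therefore gives an at least 1.2-fold higher number from compound 3 to compound 4 (0.11 log units; that floor lies within the scatter) and so fits the rise seen on the core of compound 1 without confirming it; only the floor of the new step is known. This shows no conflict between the two cores, but it does not show that the change carries over with the same size: the same change on two cores in this assay, a 2.3-fold higher number (0.37 log units; beyond the scatter) from compound 1 to compound 2 and an at least 1.2-fold higher number (0.11 log units; that floor lies within the scatter) from compound 3 to compound 4; the limit leaves it open whether they differ.

The compounds shown have only hydrogen or chloro at this place between two ring nitrogen atoms, so what an amine or a methoxy group would do there stays open. Also open, going by these compounds, is how far compound 4 really lies from compound 3, and one value in this small set rests on such a limit: the limit of > 100000 nM in this assay, at which 1 of the 4 values shown sits.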